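Side-chain variation at the amino acid: compound 4 estimate

The source may hold more compounds than are shown below. What is called first, only, known or untested is meant among the compounds shown, and "the series" means these compounds.

Three compounds share a core carrying an amino acid bearing a cyclopropyl group. Compound 1 `C[C@H](NC(=O)CN(c1nc(Cl)nc2[nH]cnc12)C1CC1)C(=O)O` gives 43.5% in a functional assay on the whole organism (Tail, strain ICR) with Mus musculus as the target, in the tail flick test, with a stated time of 90 min, at a dose of 25 umol/kg by the oral route; a higher number here means a stronger effect of the compound at the dose given, a lower number a weaker effect. Compound 2 `O=C(O)CC[C@H](NC(=O)CN(c1nc(Cl)nc2[nH]cnc12)C1CC1)C(=O)O` gives 44.7% in this assay. Compound 3 `NC(=O)CC[C@H](NC(=O)CN(c1nc(Cl)nc2[nH]cnc12)C1CC1)C(=O)O` gives 41.1% in this assay, the lowest of the three numbers, though its gap to compound 1 and to compound 2 lies within the scatter, so no order among the three can be read.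

The steps measured so far all stay flat: a number 1.2 percentage points higher from compound 1 to compound 2 (within the scatter), a number 2.4 percentage points lower from compound 1 to compound 3 (within the scatter) and a number 3.6 percentage points lower from compound 2 to compound 3 (within the scatter). Exchanging hydrogen for carboxymethyl or carbamoylmethyl, or hydroxy for amino on the carbonyl carbon, left the read-out where it was.

Compound 4 `O=C(CN(c1nc(Cl)nc2[nH]cnc12)C1CC1)N[C@@H](CO)C(=O)O` differs from compound 3 by hydroxy in place of carbamoylmethyl on a saturated chain carbon, two bonds along the chain from an amide-type nitrogen and a carbonyl carbon. Among the compounds with values here, no measured step introduces hydroxy at this place, so the bearing steps are indirect: the removal of carbamoylmethyl reverses the change that gave a number 2.4 percentage points lower from compound 1 to compound 3 (within the scatter), which was within the scatter. The three side chains examined gave indistinguishable numbers, and the expectation is therefore that compound 4 shows no step beyond the scatter, a number 1.9 percentage points higher from compound 3 to compound 4 (within the scatter). Compound 4 is estimated at 43% in this assay, with a range from 33% to 53%.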

Compound 4, a percentage reported as activity, at one dose (the size of the read-out at that dose, not a potency): 43.9%
The estimate for compound 4 lay 0.9 percentage points below the measured number, and the stated range covers the measured number.
By their numbers in this assay, from the lowest: compounds 3, 1, 4 and 2 (each within the scatter of the next).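

Hydroxy on the saturated chain carbon, two bonds along the chain from an amide-type nitrogen and a carbonyl carbon, joins hydrogen, carboxymethyl and carbamoylmethyl as a fourth group at this place, and in this assay it shows a number 0.4 percentage points higher from compound 1 to compound 4 (within the scatter) and a number 0.8 percentage points lower from compound 2 to compound 4 (within the scatter) and a number 2.8 percentage points higher from compound 3 to compound 4 (within the scatter) with no order among the four compounds. The flat picture therefore now extends to a side chain bearing hydroxy, and the exchange of carbamoylmethyl (4 heavy atoms) for hydroxy (1 heavy atom) does not take the read-out beyond the scatter. No supporting data are available to explain why this place tolerates all four groups.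

As far as these compounds go, whether a primary amine, a phenyl ring or a longer alkyl chain at this place would also stay within the scatter remains open. Also open, from the compounds shown here alone, is whether the four compounds would still be indistinguishable at other doses or times, since a read-out at a single dose says nothing about potency.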